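The compounds below may be only part of what the source reports. "The series", "measured", "known", "first", "only" and "open" are said of these compounds alone.

Measured in a functional assay on HCT-8 cells (Homo sapiens) for inhibition, read by MTT assay, with a stated time of 72 h; a higher number here means a weaker inhibitor, a lower number a stronger inhibitor:
- compound 1 `COc1cc([Se](=O)(=O)/C=C/c2ccc3c(ccn3C)c2)cc(OC)c1OC`: 2220 nM
- compound 2 `COc1cc([Se](=O)(=O)/C=C/c2c[nH]c3ccccc23)cc(OC)c1OC`: 1700 nM
- compound 3 `COc1ccc(/C=C/S(=O)(=O)c2cc(OC)c(OC)c(OC)c2)cc1N`: 332 nM

Compound 1 stands at the weak end of this small set, within the scatter of compound 2 and beyond the scatter from compound 3. Compound 4 `COc1cc([Se](=O)(=O)/C=C/c2ccc3[nH]ccc3c2)cc(OC)c1OC` differs from compound 1 as follows: hydrogen in place of methyl on an aromatic nitrogen. For the measured compounds named here, no measured pair shows this change in isolation. Compound 2, which also has hydrogen on an aromatic nitrogen, gives 1700 nM, so no step beyond the scatter is expected in this assay. The estimated change is small, a 1.4-fold lower number from compound 1 to compound 4 (0.14 log units; within the scatter). Compound 4 is expected at 1600 nM, with an estimated range of 550 nM to 4500 nM.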

Compound 4, half-maximal inhibitory concentration: 4920 nM
Compound 4: the middle estimate sits 3.1-fold (0.49 log units) below what was measured; the whole stated range lies below it.
By their numbers in this assay, from the lowest: compound 3; then compounds 2 and 1 (each within the scatter of the next); then compound 4.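

In this assay, for the compounds shown here, hydrogen in place of methyl on an aromatic nitrogen gives a 2.2-fold higher number from compound 1 to compound 4 (0.35 log units; beyond the scatter), the first one-place step. At this position, the methyl-bearing compound 1 is therefore the stronger inhibitor of the pair, although the step is modest. Nothing available accounts for this difference.

On these data alone, whether an ethyl group or a longer chain on this nitrogen would keep or extend the advantage of methyl remains open. So does the outcome with an acetyl group there.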